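Swapping the amine for a methylsulfonyl piperazine

This account rests on a few compounds, and the source may have more. Where it says the series, first, only, none or still open, it means among the compounds named here.

In an ADME assay on MT4 cells (Homo sapiens) for cytotoxicity, read by MTT assay, with a stated time of 5 days (on this read-out lower numbers stand for higher toxicity in this test and higher numbers for lower toxicity in this test), three compounds have been measured so far:
Compound 1, `Cc1cc(/C=C/C#N)cc(C)c1Oc1nc(Nc2ccc(N3CCCC(NS(N)(=O)=O)C3)cc2)nc2sccc12`: > 217000 nM
Compound 2, `Cc1cc(/C=C/C#N)cc(C)c1Oc1nc(Nc2ccc(N3CCN(S(N)(=O)=O)CC3)cc2)nc2sccc12`: > 222000 nM
Compound 3, `Cc1cc(/C=C/C#N)cc(C)c1Oc1nc(Nc2ccc(N3CCCC(N)C3)cc2)nc2sccc12`: 4610 nM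

Compound 3 is the only one of the three whose reading is an actual number. For compound 1 the reading is a limit of the test rather than a number, namely (the limit of > 217000 nM in this assay, at which 1 of the 3 values shown sits). For compound 2 it is likewise a limit, (the limit of > 222000 nM in this assay, at which 1 of the 3 values shown sits). Both steps toward compound 3 were large: an at least 47-fold lower number from compound 1 to compound 3 (1.67 log units; beyond the scatter), with hydrogen in place of sulfamoyl on an amine nitrogen, and an at least 48-fold lower number from compound 2 to compound 3 (1.68 log units; beyond the scatter), with 3-aminopiperidin-1-yl in place of 4-sulfamoylpiperazin-1-yl on an aromatic carbon. The step between compound 1 and compound 2 cannot be read, a step that the two limits leave unreadable from compound 1 to compound 2.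

Compound 4, `Cc1cc(/C=C/C#N)cc(C)c1Oc1nc(Nc2ccc(N3CCN(S(C)(=O)=O)CC3)cc2)nc2sccc12`, has not yet been measured. It differs from compound 3 by 4-(methylsulfonyl)piperazin-1-yl in place of 3-aminopiperidin-1-yl on an aromatic carbon. This largely reverses the change from compound 2 to compound 3, with a methylsulfonyl group on the piperazine where compound 2 carries a sulfamoyl group. Both measured steps that led to compound 3 gave a large drop in the number; running the other way, a large rise is expected for compound 4, a 43-fold higher number from compound 3 to compound 4 (1.64 log units; beyond the scatter). Compound 4 is therefore estimated at 200000 nM, with a range from 50000 nM to 500000 nM, and it may well be reported only as a limit.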

Compound 4, half-maximal cytotoxic concentration: > 222000 nM
Compound 4 was reported as a limit (the forecaster's own chance of this, stated with the estimate: 75%); middle value at least 1.1-fold (0.04 log units) from the limit.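

In this assay, 4-(methylsulfonyl)piperazin-1-yl in place of 3-aminopiperidin-1-yl on the aromatic carbon gives an at least 48-fold higher number from compound 3 to compound 4 (1.68 log units; beyond the scatter), which shows that a high reading at this position does not depend on a sulfamoyl group. Methyl can stand in place of amino on the sulfonyl sulfur and the reading is still a limit of the test, so among the four compounds all three sulfonyl compounds read at a limit, the only actual number belongs to compound 3 with its free amine, and no compound goes against this. The steps to compound 4 from compound 1 and from compound 2 cannot be read, because those readings are limits and not numbers: the limit of > 222000 nM in this assay, at which 2 of the 4 values shown sit.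

The compounds shown leave open whether the free amine or the piperidine ring goes with the low number, which a piperazine with an unsubstituted ring nitrogen, or a 3-(methylsulfonylamino)piperidine, would help to separate. From the compounds shown here alone, it is also open whether a non-sulfonyl cap on the piperazine, such as an acetyl group, would read at the limit as well.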